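Compound 4: isopropyl enters where compound 3 carries hydrogen

The source may hold more compounds than are shown below. What is called first, only, known or untested is meant among the compounds shown, and "the series" means these compounds.

Three compounds have been measured in a functional assay on the whole organism (Tail, strain ICR) with Mus musculus as the target, in the tail flick test, with a stated time of 90 min, at a dose of 25 umol/kg by the oral route; a higher number here means a stronger effect of the compound at the dose given, a lower number a weaker effect:
compound 1 `CSCC[C@H](NC(=O)CN(c1nc(Cl)nc2[nH]cnc12)C1CC1)C(=O)OCc1ccccc1` gives 44.6%
compound 2 `NCCCC[C@H](NC(=O)CN(c1nc(Cl)nc2[nH]cnc12)C1CC1)C(=O)OCc1ccccc1` gives 35.3%
compound 3 `O=C(CN(c1nc(Cl)nc2[nH]cnc12)C1CC1)NCC(=O)OCc1ccccc1` gives 27.2%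

Compound 3 stands lowest of the three numbers. Its nearest neighbour is compound 2, a step of a number 8.1 percentage points lower from compound 2 to compound 3 (within the scatter), which stays within the scatter; its furthest is compound 1, a step of a number 17.4 percentage points lower from compound 1 to compound 3 (beyond the scatter), which lies beyond it. Compound 4 `CC(C)[C@H](NC(=O)CN(c1nc(Cl)nc2[nH]cnc12)C1CC1)C(=O)OCc1ccccc1` has not yet been measured. It differs from compound 3 in one place: isopropyl in place of hydrogen on a saturated chain carbon bound to an amide-type nitrogen and a carbonyl carbon. Going by the values given here, two measured steps bear on this change, since both put a group in place of hydrogen at the same place: the step of a number 17.4 percentage points lower from compound 1 to compound 3 (beyond the scatter) is modest, and the step of a number 8.1 percentage points lower from compound 2 to compound 3 (within the scatter) is within the scatter. Going from hydrogen to a group has therefore either raised the read-out modestly or left it within the scatter. Compound 4 is thus expected to come out somewhat higher than compound 3, with a step of a number 9.8 percentage points higher from compound 3 to compound 4 (within the scatter). The estimate for compound 4 in this assay is 37%, within a range from 24% to 50%.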

Compound 4, a percentage reported as activity, at one dose (the size of the read-out at that dose, not a potency): 51.3%
Compound 4: the middle estimate sits 14.3 percentage points below what was measured, outside the stated range (above it).
By their numbers in this assay, from the lowest: compounds 3, 2, 1 and 4 (each within the scatter of the next, the first and the last beyond it).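

In this assay, the step of a number 24.1 percentage points higher from compound 3 to compound 4 (beyond the scatter) shows that replacing hydrogen at this saturated chain carbon with isopropyl, a group with no ring and no hydrogen-bond donors or acceptors, is enough to move the read-out beyond the scatter, which 4-aminobutyl did not do. The step of a number 16 percentage points higher from compound 2 to compound 4 (beyond the scatter) also separates isopropyl from 4-aminobutyl at this position, so the two groups are not interchangeable here. By contrast, the step of a number 6.7 percentage points higher from compound 1 to compound 4 (within the scatter) does not separate isopropyl from 2-(methylsulfanyl)ethyl, so these two chains cannot be ranked.

The compounds shown leave open how a methyl group, a longer alkyl chain, a phenyl ring or a carboxylic acid would behave at this carbon. Nothing available explains why these groups differ.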